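Thioether chain length and thromboxane receptor inhibition

A few compounds are considered here, and "the series" means these few. Any claim that something is new, unique, unknown or untested is made for them only; others in the source may bear on it.

Measured compounds:
compound 1 `O=C(O)CCC/C=C\CC1C2CCC(O2)C1CSCCCc1ccccc1` gives 5000 nM in a functional assay on a cell-free system (plasma) for inhibition of thromboxane A2 receptor (Homo sapiens); on this read-out lower numbers stand for stronger inhibition and higher numbers for weaker inhibition
compound 2 `CCCCCCCCSCC1C2CCC(O2)C1C/C=C\CCCC(=O)O` gives 547000 nM in this assay
compound 3 `CCSCC1C2CCC(O2)C1C/C=C\CCCC(=O)O` gives 5400 nM in this assay

Compound 3 stands second highest of the three numbers; its nearest neighbour is compound 1, with a 1.1-fold higher number from compound 1 to compound 3 (0.03 log units; within the scatter), and its furthest is compound 2, with a 100-fold lower number from compound 2 to compound 3 (2.01 log units; beyond the scatter). The unmeasured compound 4 `CCC/C=C/CSCC1C2CCC(O2)C1C/C=C\CCCC(=O)O` differs from compound 3 by pent-1-en-1-yl in place of methyl on a saturated chain carbon bound to a sulfur.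

Among the compounds with values here, two measured steps bear on this change. The step of a 100-fold lower number from compound 2 to compound 3 (2.01 log units; beyond the scatter) shows that a long saturated chain on the sulfur-bearing carbon goes with a far higher number than the short chain of compound 3. The step of a 110-fold higher number from compound 1 to compound 2 (2.04 log units; beyond the scatter) points the same way: a long saturated chain gives a much higher number than the phenyl-ended chain of compound 1. Within the data shown here, the chain entering in compound 4 is longer than that of compound 3 but shorter than that of compound 2, and carries a double bond for which no measured step exists. Compound 4 is therefore expected to give a higher number than compound 3, with a 5.6-fold higher number from compound 3 to compound 4 (0.74 log units; beyond the scatter) as the expected step, smaller than the step to compound 2. The estimate for compound 4 is 30000 nM, within 5000 nM to 200000 nM.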

Compound 4, half-maximal inhibitory concentration: 1300 nM
Beside the measured number, compound 4's estimate is 23-fold (1.36 log units) above it; the measured number lies below the stated range.
By their numbers in this assay, from the lowest: compound 4; then compounds 1 and 3 (each within the scatter of the next); then compound 2.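

In this assay the pent-1-en-1-yl group on a saturated chain carbon bound to a sulfur moves the number the opposite way from the long saturated chain, with a 4.2-fold lower number from compound 3 to compound 4 (0.62 log units; beyond the scatter) as the step from the short chain, so a longer chain at this place does not by itself give a higher number. Compound 2 stands against any simple rule of length, and a 420-fold lower number from compound 2 to compound 4 (2.62 log units; beyond the scatter) marks how far apart two long chains at this one place can lie, with pent-1-en-1-yl in place of heptyl. The step of a 3.8-fold lower number from compound 1 to compound 4 (0.59 log units; beyond the scatter) also carries the number past the phenyl-ended chain, which shows that the level shared by compound 1 and compound 3 was not the lowest this position can reach, and compound 4 now has the lowest number of the four.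

No evidence is at hand that accounts for these differences. The compounds shown leave open whether the lower number of compound 4 goes with its double bond or with its chain length, which a saturated hexyl chain on the same carbon would separate, and how a chain ending in an amine would read.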